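The source may hold more compounds than are shown below. What is called first, only, known or untested is meant among the compounds shown, and "the series" means these compounds.

The study concerns a small set of chalcones built on a shared core, tested in a functional assay on RL cells (Homo sapiens) for cytotoxicity, with a stated time of 48 h; a higher number here means a weaker inhibitor, a lower number a stronger inhibitor. Compound 1, `COc1cc(O)c(C(=O)/C=C/c2ccc(F)cc2)c(OC)c1`, gives in this assay 5400 nM. Compound 2, `COc1cc(OC)c(C(=O)/C=C/c2ccc(Cl)cc2)c(OC)c1`, gives in this assay 6500 nM. Compound 3, `COc1cc(O)c(C(=O)/C=C/c2ccccc2SC)c(OC)c1`, gives in this assay 8900 nM. Among these three numbers compound 2 holds the second highest, but its gaps to compound 1 and to compound 3 both sit within the usual scatter of such measurements, so the three compounds cannot be told apart on potency from these data.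

Compound 4, `COc1cc(OC)c(C(=O)/C=C/c2ccccc2)c(OC)c1`, has not yet been measured in this assay. It differs from compound 2 in one place: hydrogen in place of chloro on an aromatic carbon. The change sits on an aromatic carbon of a six-membered aromatic ring of carbon only, para to a large group, and read one bond further out it is 4-chlorophenyl to phenyl.

Among the measured compounds shown here, no pair of measured compounds differs by a single change, so the size of this step has to be judged from the narrow spread of the three values. The account expects the step from compound 2 to compound 4 to be small, a 1.2-fold higher number from compound 2 to compound 4 (0.09 log units; within the scatter), and likely not beyond the scatter. For compound 4 the estimate in this assay is 8000 nM, within a range from 3500 nM to 20000 nM.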

Compound 4, half-maximal inhibitory concentration: 6900 nM
For compound 4 the middle estimate is 1.2-fold (0.06 log units) above the measured one; measured number inside the range.
By their numbers in this assay, from the lowest: compounds 1, 2, 4 and 3 (each within the scatter of the next).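

Among the compounds shown here, the first single-place comparison in this set, hydrogen in place of chloro on an aromatic carbon, reads in this assay as a 1.1-fold higher number from compound 2 to compound 4 (0.03 log units; within the scatter). For the compounds shown here, at this position, para to a large group, compound 2 and compound 4 cannot be told apart, so the chloro is not needed to keep the number at this level on this core, something the earlier compounds, with no single-place pair among them, could not show. Nothing available here bears on why the step is so small.

Chloro and hydrogen are the only two groups compared at this position on this core, so it remains open whether an amine, a carboxylic acid or a longer chain such as n-butyl in the same place would also leave the number within the scatter. From the compounds shown here alone, compound 1 and compound 3 each differ from compound 2 in more than one place, so it is also open whether the same exchange of chloro for hydrogen would give so small a step on a core that carries a hydroxyl group.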